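The source may report more compounds than this note shows. Statements on the series, on what has been measured and on what is new or still open speak of the compounds shown alone.

Measured so far:
- compound 1 `N#Cc1ccc(Oc2cccnc2)cc1NC1CCCCC1`: in an assay on isolated protein for inhibition of Aromatase (Homo sapiens), read by fluorescence, tested at 1 uM (a higher number here means more inhibition at the concentration tested (going by the name of the read-out), a lower number less inhibition), compound 1 gives 33%
- compound 2 `COc1ccc(Oc2cc(Oc3cccnc3)ccc2C#N)cc1`: in this assay compound 2 gives 84%
- compound 3 `N#Cc1ccc(Oc2cccnc2)cc1Oc1cccc(Cl)c1`: in this assay compound 3 gives 25%

For the measured compounds named here, compound 3 holds the lowest number of the three in this assay, though its gap to compound 1 lies within the scatter; only the gap to compound 2 is beyond it, and that is the single step with one change, a number 59 percentage points lower from compound 2 to compound 3 (beyond the scatter), which swaps both the group and where it sits.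

Compound 4 `N#Cc1ccc(Oc2cccnc2)cc1Oc1ccccc1` is not yet measured. From compound 3 it differs by hydrogen in place of chloro on an aromatic carbon. Going by the values given here, no measured step removes a substituent from this ring alone, so the size of a number 59 percentage points lower from compound 2 to compound 3 (beyond the scatter) is only an indirect guide. A modest rise in this assay is expected, a number 10 percentage points higher from compound 3 to compound 4 (within the scatter), not clearly beyond the scatter. Compound 4 is estimated at 35%, within 10% to 65%.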

Compound 4, a percentage reported as inhibition, at one concentration (the size of the read-out at that concentration, not a potency): 78%
Estimate against measurement, compound 4: 43 percentage points below; measured number outside the range, above it.
By their numbers in this assay, from the lowest: compounds 3 and 1 (each within the scatter of the next); then compounds 4 and 2 (each within the scatter of the next).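

In this assay, a number 53 percentage points higher from compound 3 to compound 4 (beyond the scatter) shows that chloro on this aromatic carbon alone separates a low number from a high one. Against that, a number 6 percentage points lower from compound 2 to compound 4 (within the scatter) leaves hydrogen and methoxy unseparated, so not every substituent on this ring goes with a low number. With a number 45 percentage points higher from compound 1 to compound 4 (beyond the scatter) phenoxy also stands clearly apart from cyclohexylamino on the shared core, which places the low number of compound 3 with its chloro and not with the phenoxy link itself.

From the compounds shown here alone, whether fluoro or methyl on this carbon reads like chloro or like hydrogen stays open. The compounds shown offer no measurement that explains any of these steps.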